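This account rests on a few compounds, and the source may have more. Where it says the series, first, only, none or still open, it means among the compounds named here.

Compound 1, `O=C(CN1CCNCC1)Nc1nc2cc([N+](=O)[O-])ccc2s1`, gives 12.3% in a functional assay on the whole organism (strain Wistar) for inhibition, with Rattus norvegicus as the target, read by paw edema, with a stated time of 2 h, at a dose of 30 mg/kg; a lower number here means less inhibition, a higher number more inhibition at the dose given (going by the name of the read-out). Compound 2, `COc1ccc2sc(NC(=O)CN3CCCNCC3)nc2c1`, gives 17.4% in this assay.

Compound 2 holds the higher of the two numbers, but the gap to compound 1 lies within the usual scatter, so the two cannot be told apart. Compound 3, `O=C(CN1CCCNCC1)Nc1nc2cc([N+](=O)[O-])ccc2s1`, is not yet measured. It differs from compound 2 in one place: nitro in place of methoxy on an aromatic carbon. Compound 1 also carries a nitro group and stays within the scatter of compound 2, so the step in this assay is expected to be small, a number 2.4 percentage points lower from compound 2 to compound 3 (within the scatter), in no clear direction. Compound 3 is therefore estimated at 15%, with a range from 5% to 30%.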

Compound 3, a percentage reported as inhibition, in the whole organism at one dose (the size of the read-out at that dose, not a potency): 17.4%
The estimate for compound 3 lay 2.4 percentage points below the measured number, and the stated range covers the measured number.
By their numbers in this assay, from the lowest: compounds 1, 2 and 3 (each within the scatter of the next).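

With the 1,4-diazepan-1-yl group held constant, nitro in place of methoxy on the aromatic carbon gives no change at the digits printed from compound 2 to compound 3 (within the scatter) in this assay, so this change does not separate the two compounds. With nitro held constant, 1,4-diazepan-1-yl in place of piperazin-1-yl gives a number 5.1 percentage points higher from compound 1 to compound 3 (within the scatter), so this change does not separate them either. Nothing measured explains these results.

On these data alone, whether an amine or a chlorine on this aromatic carbon would move the number beyond the scatter remains open. So does the effect of a longer chain in place of the saturated chain carbon bound to the carbonyl carbon.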